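Replacing the Acid Chain of Compound 2 with an Amide

The source may hold more compounds than are shown below. What is called first, only, known or untested is meant among the compounds shown, and "the series" means these compounds.

Compound 2 `O=C(O)CSc1ccc(NCc2cccc(Oc3ccccc3)c2)cc1` carries the highest number of the three measured compounds in a functional assay on CHO cells for agonist activity at Free fatty acid receptor 1 (Homo sapiens) (a lower number here means that less compound is needed, a higher number that more compound is needed for the effect), giving 324 nM. Among the compounds with values here, compound 1 `Cc1nc(-c2ccc(C(F)(F)F)cc2)sc1CNc1ccc(CCC(=O)O)cc1` gives 67.6 nM, and compound 3 `Cc1nc(-c2ccc(C(F)(F)F)cc2)sc1CNc1ccc(C(C)CC(=O)O)cc1` gives 58.9 nM; the only single-point step among them, a 1.1-fold lower number from compound 1 to compound 3 (0.06 log units; within the scatter), lies within the scatter and involves no acid. Compound 4 `O=C(CCc1ccc(NCc2cccc(Oc3ccccc3)c2)cc1)N1CCCC1` differs from compound 2 in one place: 2-((pyrrolidin-1-yl)carbonyl)ethyl in place of (carboxymethyl)sulfanyl on an aromatic carbon. Within the data shown here, no measured step removes an acid or introduces an amide, so the measured steps offer no direct guide. Every measured compound keeps an acid; compound 4 does not, and it is expected to need more, the estimated step being a 9.3-fold higher number from compound 2 to compound 4 (0.97 log units; beyond the scatter). Compound 4 is estimated at 3000 nM, within 500 nM to 20000 nM.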

Compound 4, half-maximal effective concentration: 115 nM
Compound 4: middle estimate off by 26-fold (1.42 log units), on the high side; measured number outside the range, below it.
By their numbers in this assay, from the lowest: compounds 3, 1 and 4 (each within the scatter of the next); then compound 2.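

At this place on the aromatic ring, para to a large group, the compound does not depend on keeping a carboxylic acid: 2-((pyrrolidin-1-yl)carbonyl)ethyl in place of (carboxymethyl)sulfanyl gives a 2.8-fold lower number from compound 2 to compound 4 (0.45 log units; beyond the scatter) in this assay. The swap gives up the only hydrogen-bond donor of the leaving group and adds a five-membered ring, yet the number still falls. Nothing measured here explains this step.

The change also removes the sulfur and alters the chain, so the step cannot be assigned to any one of these parts. A piperidine amide or a plain propanoic acid chain on the same core would help separate them.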